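Benzofuran-2-yl in Place of Phenyl on a Shared Core

The source may hold more compounds than are shown below. What is called first, only, known or untested is meant among the compounds shown, and "the series" means these compounds.

Of the compounds shown here, three with the same core have been measured in a functional assay on K562 cells (Homo sapiens), read by MTT assay, with a stated time of 72 h; a lower number here means a stronger inhibitor, a higher number a weaker inhibitor. Compound 1 `COc1ncnc2c1c(-c1ccsc1)cn2[C@@H]1O[C@H](CO)[C@@H](O)[C@H]1O` gives 3450 nM, and compound 2 `COc1ncnc2c1c(-c1cccs1)cn2[C@@H]1O[C@H](CO)[C@@H](O)[C@H]1O` gives 6200 nM; the step of a 1.8-fold higher number from compound 1 to compound 2 (0.25 log units; within the scatter) separates them. On these data alone, compound 3 `COc1ncnc2c1c(-c1ccccc1)cn2[C@@H]1O[C@H](CO)[C@@H](O)[C@H]1O` reaches only a limit of the assay, > 20000 nM, so its true number is unknown. For the measured compounds named here, compound 3 thus stands at the weak end of the set: the steps of an at least 5.7-fold higher number from compound 1 to compound 3 (0.76 log units; beyond the scatter) and an at least 3.2-fold higher number from compound 2 to compound 3 (0.50 log units; beyond the scatter) both run toward weaker inhibition when phenyl replaces a thiophene, and the one value sitting at the limit of > 20000 nM in this assay, at which 1 of the 3 values shown sits, is that of compound 3.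

Compound 4 `COc1ncnc2c1c(-c1cc3ccccc3o1)cn2[C@@H]1O[C@H](CO)[C@@H](O)[C@H]1O` is not yet measured. It differs from compound 3 by 1-benzofuran-2-yl in place of phenyl on an aromatic carbon. The two steps that bear on this change are those from the thiophenes to phenyl, an at least 5.7-fold higher number from compound 1 to compound 3 (0.76 log units; beyond the scatter) and an at least 3.2-fold higher number from compound 2 to compound 3 (0.50 log units; beyond the scatter), both pointing the same way: a five-membered ring with one hetero atom at this position gave a modestly lower number than phenyl. Since 1-benzofuran-2-yl again places a five-membered ring with one hetero atom at that carbon, compound 4 is expected to move back toward the thiophene compounds, with a step of an at least 2.5-fold lower number from compound 3 to compound 4 (0.39 log units; beyond the scatter) in this assay. Compound 4 is therefore estimated at 8000 nM, within a range from 2000 nM to 30000 nM.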

Compound 4, half-maximal inhibitory concentration: 13100 nM
For compound 4 the middle estimate is 1.6-fold (0.21 log units) below the measured one; the range from low to high includes it.
By their numbers in this assay, from the lowest: compounds 1 and 2 (each within the scatter of the next); then compound 4. At a limit, above all of these: compound 3.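

In this assay, the 1-benzofuran-2-yl group shows that a five-membered aromatic ring with one hetero atom on this aromatic carbon does not by itself bring back the numbers of the thiophenes: the two comparisons read a 2.1-fold higher number from compound 2 to compound 4 (0.32 log units; beyond the scatter) and a 3.8-fold higher number from compound 1 to compound 4 (0.58 log units; beyond the scatter). The gain over phenyl cannot be sized, as the step reads an at least 1.5-fold lower number from compound 3 to compound 4 (0.18 log units; that floor lies within the scatter), so this change gives a measurable number but its floor does not clear the scatter. Compound 3 itself remains without a number, as a limit of the assay: the limit of > 20000 nM in this assay, at which 1 of the 4 values shown sits.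

The compounds shown leave open whether the gap between compound 4 and the thiophene compounds goes with the added six-membered aromatic ring or with oxygen in place of sulfur; a furan-2-yl or a 1-benzothiophen-2-yl group on this carbon would separate the two. Also open, on these data alone, is how an amine or a carboxylic acid carried on the thiophene ring would shift the number in this assay.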